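Amine nitrogen substituent: from isopropyl to butyl

This account rests on a few compounds, and the source may have more. Where it says the series, first, only, none or still open, it means among the compounds named here.

Measured in a functional assay on the whole organism with Rattus norvegicus as the target; on this read-out higher numbers stand for an effect only at larger amounts of compound and lower numbers for an effect already at smaller amounts
compound 1 `CCN(CCNC(=O)c1cc(Cl)c(N)cc1OC)Cc1ccc(Cl)cc1` gives 0.24 mg/kg
compound 2 `CCCN(CCNC(=O)c1cc(Cl)c(N)cc1OC)Cc1ccc(Cl)cc1` gives 3 mg/kg
compound 3 `COc1cc(N)c(Cl)cc1C(=O)NCCN(Cc1ccc(Cl)cc1)C(C)C` gives 3 mg/kg

Together with compound 2, compound 3 holds the highest number of the three at 3 mg/kg in this short series. Still unmeasured is compound 4 `CCCCN(CCNC(=O)c1cc(Cl)c(N)cc1OC)Cc1ccc(Cl)cc1`, which carries butyl in place of isopropyl on an amine nitrogen. For the measured compounds named here, three measured steps bear on this change. Two were large, namely a 13-fold higher number from compound 1 to compound 2 (1.10 log units; beyond the scatter) and a 13-fold higher number from compound 1 to compound 3 (1.10 log units; beyond the scatter). The third, no change at the digits printed from compound 2 to compound 3 (within the scatter), lay within the scatter, so propyl and isopropyl on that nitrogen read alike. Going by the values given here, no measured compound carries butyl, and the large steps leave a higher number possible. Even so, the flat third step gives no ground to expect a clear move. In this assay, from the compounds shown here alone, the expected step is a 1.3-fold higher number from compound 3 to compound 4 (0.12 log units; within the scatter) and a wide range stays open. The estimate for compound 4 is 4 mg/kg, expected to fall from 1 mg/kg to 12 mg/kg.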

Compound 4, dose for half-maximal effect: 20 mg/kg
Compound 4: the middle estimate sits 5.0-fold (0.70 log units) below what was measured; the measured number lies above the stated range.
By their numbers in this assay, from the lowest: compound 1; then compounds 2 and 3 (each within the scatter of the next); then compound 4.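

Propyl and isopropyl on the amine nitrogen read alike in this assay, but that flatness does not extend to butyl: a 6.7-fold higher number from compound 3 to compound 4 (0.82 log units; beyond the scatter), and a 6.7-fold higher number from compound 2 to compound 4 (0.82 log units; beyond the scatter). The position therefore still responds to the chain beyond propyl, and across the straight chains the whole span is an 83-fold higher number from compound 1 to compound 4 (1.92 log units; beyond the scatter), with the number rising at each lengthening from ethyl through propyl to butyl. The same change read on two cores gives steps of matching size: the same change on two cores in this assay, a 13-fold higher number (1.10 log units; beyond the scatter) from compound 1 to compound 3 and a 6.7-fold higher number (0.82 log units; beyond the scatter) from compound 2 to compound 4, 1.9-fold (0.27 log units) apart, within the scatter of two such steps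

The compounds shown leave open whether a longer chain such as pentyl continues this rise or levels off. Also open, from the compounds shown here alone, is whether methyl on that nitrogen would extend the trend below compound 1, and how a ring-bearing group such as cyclopropylmethyl would read.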